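Adding a Methoxy to Compound 2

This account rests on a few compounds, and the source may have more. Where it says the series, first, only, none or still open, it means among the compounds named here.

Two related compounds have been tested so far, and only one of them has a true number. In a functional assay on MT4 cells (Homo sapiens) for cytotoxicity (on this read-out higher numbers stand for weaker inhibition and lower numbers for stronger inhibition), compound 1 `COc1cccc([S+]([O-])c2cccc(N)c2C#N)c1` gives > 80000 nM, which is a limit of the assay and not a number. In this assay, going by the values given here, compound 2 `N#Cc1c(N)cccc1[S+]([O-])c1cccc(C(F)(F)F)c1` gives 125000 nM, the only actual number available and therefore the sole reference point.

Compound 3 `COc1cc([S+]([O-])c2cccc(N)c2C#N)cc(C(F)(F)F)c1` keeps the trifluoromethyl group of compound 2 and gains one more group: methoxy in place of hydrogen on an aromatic carbon. In words, this is methoxy in place of hydrogen on an aromatic carbon.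

Among the compounds with values here, the only measured step that bears on this change is a step that the limit leaves unreadable from compound 1 to compound 2. On these data alone, its size stays unknown because of the limit of > 80000 nM in this assay, at which 1 of the 2 values shown sits. That step involves the same methoxy group, but it offers no size to carry over, so no shift beyond the usual scatter is expected in this assay, in either direction.

The expected change is a 1.1-fold lower number from compound 2 to compound 3 (0.06 log units; within the scatter). The estimate for compound 3 is 110000 nM, with an expected range from 50000 nM to 220000 nM.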

Compound 3, half-maximal inhibitory concentration: 108000 nM
Estimate against measurement, compound 3: 1.0-fold (0.01 log units) above; low and high end bracket the measured number.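

In this assay, placing a methoxy group on an aromatic carbon meta to a trifluoromethyl group gives a 1.2-fold lower number from compound 2 to compound 3 (0.06 log units; within the scatter). Going by these compounds alone, this is the first readable size for adding methoxy at this position, and it shows that with the trifluoromethyl group already present, the new group leaves compound 3 indistinguishable from compound 2 on this read-out. The other comparison involving compound 3, the one with compound 1, adds no size, and neither does the earlier step between compound 1 and compound 2, because neither of these steps can be read: the limit of > 80000 nM in this assay, at which 1 of the 3 values shown sits.

Within the data shown here, the separate contribution of the trifluoromethyl group therefore remains unknown for a compound that also carries methoxy, since the only comparison bearing on it has no readable size. On these data alone, it also remains open whether a different group on this same aromatic carbon, such as an amine, a carboxylic acid or a longer chain like butoxy, would move the number in this assay beyond the usual scatter of repeated measurements.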